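Dropping the methoxy from a tetradecyl serinamide Schiff base

The source may report more compounds than this note shows. Statements on the series, on what has been measured and on what is new or still open speak of the compounds shown alone.

Measured compounds:
- compound 1, `CCCCCCCCCCCCCCNC(=O)[C@H](CO)/N=C/c1ccc(OC)cc1`: 28100 nM in a functional assay on cells (Homo sapiens) for cytotoxicity, read by MTT assay, with a stated time of 24 h; a higher number here means a weaker inhibitor, a lower number a stronger inhibitor
- compound 2, `CCCCCCCCCCCCCCNC(=O)[C@H](CO)NCc1ccccc1O`: 75300 nM
- compound 3, `CCCCCCCCCCCCCCNC(=O)[C@H](CO)/N=C/c1ccc(O)cc1`: 19300 nM

Compound 1 gives the second highest of the three numbers in this assay. Its nearest neighbour is compound 3, which lies within the scatter of it, while compound 2 is the furthest, with a 2.7-fold higher number from compound 1 to compound 2 (0.43 log units; beyond the scatter).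

Compound 4, `CCCCCCCCCCCCCCNC(=O)[C@H](CO)/N=C/c1ccccc1`, differs from compound 1 by a single change: hydrogen in place of methoxy on an aromatic carbon

Within the data shown here, the step that bears most on this change is the one from compound 1 to compound 3, which also alters the same substituent on the ring: a 1.5-fold lower number from compound 1 to compound 3 (0.16 log units; within the scatter). That step stayed within the scatter, and the change to compound 4 removes the whole group at that position rather than shortening it. Among the measured compounds shown here, no measured pair in this set shows the removal of the group entirely, so the expectation rests on the one nearby step. The estimate for compound 4 is therefore a number close to that of compound 1, with no step beyond the scatter expected in this assay, written as a 1.1-fold higher number from compound 1 to compound 4 (0.03 log units; within the scatter). Compound 4 is expected to give about 30000 nM, with a likely range from 13000 nM to 70000 nM.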

Compound 4, half-maximal inhibitory concentration: 7670 nM
Estimate against measurement, compound 4: 3.9-fold (0.59 log units) above, and the stated range ends above it.
By their numbers in this assay, from the lowest: compound 4; then compounds 3 and 1 (each within the scatter of the next); then compound 2.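

In this assay, the full removal of the methoxy gives a 3.7-fold lower number from compound 1 to compound 4 (0.56 log units; beyond the scatter), a step beyond the scatter, whereas replacing methyl with hydrogen on the same oxygen gave only a 1.5-fold lower number from compound 1 to compound 3 (0.16 log units; within the scatter), within the scatter. Removing the hydroxy also gives a step beyond the scatter, a 2.5-fold lower number from compound 3 to compound 4 (0.40 log units; beyond the scatter), so at this place on the ring, the change that registers is losing the oxygen-bearing group altogether, and compound 4 now has the lowest number of the set. The widest step, a 9.8-fold lower number from compound 2 to compound 4 (0.99 log units; beyond the scatter), replaces the whole group on the saturated chain carbon, so it cannot be assigned to one feature of that group.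

Nothing shown here accounts for these steps. On these data alone, it also remains open how a chlorine, a fluorine or an amine would read at this place on the ring, and whether the phenyl result would hold with a chain shorter than tetradecyl.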